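The source may report more compounds than this note shows. Statements on the series, on what has been measured and on what is new or still open speak of the compounds shown alone.

Compound 1 `NC(=O)c1c(NC(=O)c2ccccc2Cl)sc2c1CCN(Cc1ccccc1F)C2` carries a 2-fluorobenzyl group on the ring amine of a shared core. In a functional assay on MKN-74 cells (Homo sapiens) for antiproliferative activity, with a stated time of 24 h (a lower number here means a stronger inhibitor, a higher number a weaker inhibitor), compound 1 gives 12900 nM, and compound 2 `NC(=O)c1c(NC(=O)c2ccccc2Cl)sc2c1CCN(C(=S)Nc1cccc3ccccc13)C2` gives 20700 nM; these two numbers lie within the scatter of each other, so neither can be called the stronger of the pair.

Compound 3 `NC(=O)c1c(NC(=O)c2ccccc2Cl)sc2c1CCN(C(=O)Nc1c(Cl)cccc1Cl)C2` differs from compound 1 in one place: (2,6-dichlorophenyl)carbamoyl in place of 2-fluorobenzyl on an amine nitrogen in a ring. Among the compounds with values here, no measured pair shows this kind of change, so only the two values above guide an expectation, and they suggest a step from compound 1 to compound 3 of a 1.2-fold higher number from compound 1 to compound 3 (0.07 log units; within the scatter), that is, none beyond the scatter. Compound 3 is therefore estimated at 15000 nM, with a range from 5000 nM to 45000 nM.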

Compound 3, half-maximal inhibitory concentration: 24400 nM
Compound 3: middle estimate off by 1.6-fold (0.21 log units), on the low side; the range from low to high includes it.
By their numbers in this assay, from the lowest: compounds 1, 2 and 3 (each within the scatter of the next).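

Within the data shown here, this is the first comparison at the ring amine nitrogen that changes one place only: in this assay the swap to (2,6-dichlorophenyl)carbamoyl gives a 1.9-fold higher number from compound 1 to compound 3 (0.28 log units; within the scatter) and so stays within the usual scatter. This position therefore takes a group with one hydrogen-bond donor and one acceptor, where 2-fluorobenzyl has neither, with no change that can be read. No measurement here bears on the reason for this result.

Going by these compounds, whether an amine or a carboxylic acid at this nitrogen would move the number beyond the scatter remains open.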